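A few compounds are considered here, and "the series" means these few. Any claim that something is new, unique, unknown or untested is made for them only; others in the source may bear on it.

Compound 1 `C=C[C@]1(C)C[C@@H](OC(=O)CNC(=O)Nc2ccc(OC)cc2)[C@]2(C)[C@H](C)CC[C@]3(CCC(=O)[C@H]32)[C@@H](C)[C@@H]1O`: > 10000 nM
Compound 2 `C=C[C@]1(C)C[C@@H](OC(=O)CNC(=O)Nc2cccc(Br)c2)[C@]2(C)[C@H](C)CC[C@]3(CCC(=O)[C@H]32)[C@@H](C)[C@@H]1O`: 3950 nM
Compound 3 `C=C[C@]1(C)C[C@@H](OC(=O)CNC(=O)Nc2ccc(Cl)cc2)[C@]2(C)[C@H](C)CC[C@]3(CCC(=O)[C@H]32)[C@@H](C)[C@@H]1O`: > 10000 nM

All three were tested in a functional assay on HGC-27 cells (Homo sapiens) for inhibition, read by MTT assay, with a stated time of 72 h; a higher number here means a weaker inhibitor, a lower number a stronger inhibitor. Compound 3 gives > 10000 nM, which is a limit of the assay and not a number. Compound 1 gives > 10000 nM, also a limit. Together they make up (the limit of > 10000 nM in this assay, at which 2 of the 3 values shown sit). Only compound 2 has a true number, 3950 nM.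

Compound 4 `C=C[C@]1(C)C[C@@H](OC(=O)CNC(=O)Nc2ccc(F)cc2)[C@]2(C)[C@H](C)CC[C@]3(CCC(=O)[C@H]32)[C@@H](C)[C@@H]1O` differs from compound 3 by a single swap, fluoro in place of chloro on an aromatic carbon. Within the data shown here, no measured pair makes this exact swap. Replacing methoxy with chloro gave a step that the two limits leave unreadable from compound 1 to compound 3. Replacing 4-methoxyphenyl with 3-bromophenyl gave an at least 2.5-fold lower number from compound 1 to compound 2 (0.40 log units; beyond the scatter), and replacing 3-bromophenyl with 4-chlorophenyl gave an at least 2.5-fold higher number from compound 2 to compound 3 (0.40 log units; beyond the scatter). Given that last step, 4-fluorophenyl is expected to behave like 4-chlorophenyl in this assay, with no step beyond the scatter and quite possibly another limit. The expected change is a number no higher from compound 3 to compound 4 (the limit leaves the size open). For compound 4 the estimate is 10000 nM, with an expected range of 4000 nM to 25000 nM.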

Compound 4, half-maximal inhibitory concentration: > 10000 nM
Compound 4 was reported as a limit; the forecaster's own chance of this, stated with the estimate: 65%; the middle value lies on the limit itself.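

In this assay compound 4 gives > 10000 nM, which is a limit of the assay and not a number. Among these compounds, the one new step that can be read is an at least 2.5-fold higher number from compound 2 to compound 4 (0.40 log units; beyond the scatter), while the steps among compounds 1, 3 and 4 cannot be read. Fluoro now joins chloro and methoxy as a third group on the aromatic carbon para to a large group that leaves the compound at the limit, and only compound 2, with its 3-bromophenyl, goes against this pattern: the limit of > 10000 nM in this assay, at which 3 of the 4 values shown sit.

The compounds shown leave open whether the true number of compound 2 goes with the bromine or with its place on the ring, which 4-bromophenyl or 3-chlorophenyl on the same nitrogen would separate. They also leave open what an amine or a carboxylic acid on this ring would give.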